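Estimating a dialkylamino swap on a fused triazine core

This account rests on a few compounds, and the source may have more. Where it says the series, first, only, none or still open, it means among the compounds named here.

Measured so far in an assay on cell membranes for displacement of a labelled ligand from corticotropin-releasing factor receptor 1 (Rattus norvegicus); on this read-out lower numbers stand for stronger inhibition and higher numbers for weaker inhibition:
Compound 1 `CCCN(C)c1nc(C)nc2c(-c3c(C)cc(OC)cc3OC)c(C)nn12` gives 6.48 nM.
Compound 2 `CCN(CCC#N)c1nc(C)nc2c(-c3c(C)cc(OC)cc3OC)c(C)nn12` gives 2.48 nM.
Compound 3 `COc1ccc(-c2c(C)nn3c(NC4CCC4)nc(C)nc23)c(C)c1` gives 24.6 nM.

Compound 3 stands at the weakest end of the three in this assay; its number is the highest, and the gaps to compound 1 and to compound 2 both lie beyond the usual scatter. Compound 4 `CCCCN(CC)c1nc(C)nc2c(-c3ccc(OC)cc3C)c(C)nn12` has not yet been measured. It differs from compound 3 in one place: butyl(ethyl)amino in place of cyclobutylamino on an aromatic carbon. Going by the values given here, only one measured step touches the same position, and it compares two groups that are already of the dialkyl type on a different core: a 2.6-fold lower number from compound 1 to compound 2 (0.42 log units; beyond the scatter). No measured step compares a cyclobutylamino group with a dialkylamino group, so the direction for compound 4 is not directly shown. Still, both dialkylamino compounds, compound 1 and compound 2, carry numbers well below that of compound 3, so a lower number is expected for compound 4, by a modest step, a 3.1-fold lower number from compound 3 to compound 4 (0.49 log units; beyond the scatter). The expected value for compound 4 in this assay is 8 nM, with a range from 2.5 nM to 25 nM.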

Compound 4, half-maximal inhibitory concentration: 2.3 nM
Estimate against measurement, compound 4: 3.5-fold (0.54 log units) above; the whole stated range lies above it.
By their numbers in this assay, from the lowest: compounds 4 and 2 (each within the scatter of the next); then compound 1; then compound 3.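

In this assay, this swap gives an 11-fold lower number from compound 3 to compound 4 (1.03 log units; beyond the scatter), a large step and the first measured one at this position that leaves a cyclobutylamino group for an open-chain dialkylamino group. Going by these compounds alone, the earlier step compared only two dialkylamino groups, so this result adds that the choice between these two kinds of amino group can matter more here than that earlier change did. The swap removes the four-membered ring and the hydrogen-bond donor and also adds heavy atoms, and nothing available explains the size of the step.

The compounds shown leave open which of these differences carries the step. A butylamino group, which keeps the amine hydrogen without the ring, or a cyclobutyl(methyl)amino group, which keeps the ring without that hydrogen, would help to separate them.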